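Bromo in Place of Fluoro on a Shared Core

The source may hold more compounds than are shown below. What is called first, only, known or untested is meant among the compounds shown, and "the series" means these compounds.

Measured so far:
- compound 1 `COc1ccc(-c2cn3ccnc3c(-c3ccc4ncn(C5CCCCC5)c4c3)n2)cc1`: 83.2%
- compound 2 `Fc1ccc(-c2cn3ccnc3c(-c3ccc4ncn(C5CCCCC5)c4c3)n2)cc1`: 11.2%

In a functional assay on 786-0 cells (Homo sapiens) for inhibition, read by sulforhodamine B assay, with a stated time of 48 h, tested at 10 uM (on this read-out lower numbers stand for less inhibition and higher numbers for more inhibition at the one concentration tested (going by the name of the read-out)), compound 2 stands lowest of the two numbers; its nearest neighbour is compound 1, and the step of a number 72 percentage points lower from compound 1 to compound 2 (beyond the scatter) is large and beyond the scatter. Compound 3 `Brc1ccc(-c2cn3ccnc3c(-c3ccc4ncn(C5CCCCC5)c4c3)n2)cc1` differs from compound 2 by bromo in place of fluoro on an aromatic carbon. Going by the values given here, no measured step involves a bromo group, so the one known step, which concerns a methoxy group, does not bear directly on this change. The step of a number 13.8 percentage points higher from compound 2 to compound 3 (beyond the scatter) is therefore expected to be modest, near the scatter. Compound 3 is estimated at 25%, within 5% to 60%.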

Compound 3, a percentage reported as inhibition, at one concentration (the size of the read-out at that concentration, not a potency): 18%
Compound 3: middle estimate off by 7 percentage points, on the high side, and the stated range covers the measured number.
By their numbers in this assay, from the lowest: compounds 2 and 3 (each within the scatter of the next); then compound 1.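

In this assay the change from fluoro to bromo at this position gives a number 6.8 percentage points higher from compound 2 to compound 3 (within the scatter) and so shows no readable difference between these two halogens. The large gap to the methoxy compound also appears with a second halogen, as seen in a number 65.2 percentage points lower from compound 1 to compound 3 (beyond the scatter) on the shared core. No measured evidence explains either step. Still open, on these data alone, is how an amine, a hydroxyl group or a longer chain such as ethoxy would read at this same place. These compounds also cannot show whether the high number belongs to methoxy alone.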